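Ester Tail Swap on a Shared Core: Cytotoxicity Outlook

The compounds below may be only part of what the source reports. "The series", "measured", "known", "first", "only" and "open" are said of these compounds alone.

Compound 3 `O=C(CCOc1ccccc1)OCCc1c(-c2ccccc2Cl)c2cc(Cl)ccc2[nH]c1=O` gives 46000 nM in an ADME assay on HepG2 2.2.15 cells (Homo sapiens) for cytotoxicity; on this read-out lower numbers stand for higher toxicity in this test and higher numbers for lower toxicity in this test. Compound 1 `CCCC(=O)OCCc1c(-c2ccccc2Cl)c2cc(Cl)ccc2[nH]c1=O` sits alongside it, with 52000 nM, and the step of a 1.1-fold lower number from compound 1 to compound 3 (0.05 log units; within the scatter). For compound 2 `CC12CCC(C(=O)OCCc3c(-c4ccccc4Cl)c4cc(Cl)ccc4[nH]c3=O)(OC1=O)C2(C)C` the assay reports only a limit, > 1800000 nM. Compound 4 `C/C=C(\C)C(=O)OCCc1c(-c2ccccc2Cl)c2cc(Cl)ccc2[nH]c1=O` differs from compound 3 by 1-methylprop-1-en-1-yl in place of 2-phenoxyethyl on a carbonyl carbon. Earlier changes on the carbonyl carbon were large in this assay: an at least 34-fold higher number from compound 1 to compound 2 (1.53 log units; beyond the scatter) and an at least 39-fold lower number from compound 2 to compound 3 (1.59 log units; beyond the scatter), with compound 2 sitting at a limit (the limit of > 1800000 nM in this assay, at which 1 of the 3 values shown sits). The change to compound 4 is small in atom count, more like the small groups of compound 1 and compound 3 than the bulky tail of compound 2, so a step within the scatter is expected, a 1.1-fold higher number from compound 3 to compound 4 (0.04 log units; within the scatter). Compound 4 is therefore estimated at 50000 nM, ranging from 18000 nM to 140000 nM.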

Compound 4, half-maximal cytotoxic concentration: 350000 nM
For compound 4 the middle estimate is 7.0-fold (0.85 log units) below the measured one; the whole stated range lies below it.
By their numbers in this assay, from the lowest: compounds 3 and 1 (each within the scatter of the next); then compound 4. At a limit, above all of these: compound 2.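

In this assay, a small tail on this carbonyl carbon can also move the number: a 6.7-fold higher number from compound 1 to compound 4 (0.83 log units; beyond the scatter), and a 7.6-fold higher number from compound 3 to compound 4 (0.88 log units; beyond the scatter), although propyl and 2-phenoxyethyl gave values within the scatter of each other. A step beyond the scatter therefore does not require a group as large as that of compound 2, since 1-methylprop-1-en-1-yl has no ring. The remaining step, an at least 5.1-fold lower number from compound 2 to compound 4 (0.71 log units; beyond the scatter), is only a bound resting on a limit: the limit of > 1800000 nM in this assay, at which 1 of the 4 values shown sits.

The compounds shown leave open whether the double bond or the branching carries the step, and whether a saturated branched chain or an amine on the tail would behave alike.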